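The compounds below may be only part of what the source reports. "The series", "measured", "known", "first", "only" and "open" are said of these compounds alone.

Working notes on the series. In an ADME assay on cells (Homo sapiens) for cytotoxicity, read by resazurin assay, with a stated time of 5 days (on this read-out higher numbers stand for lower toxicity in this test and lower numbers for higher toxicity in this test), compound 1 (`COc1ccc(-c2nc(CCc3cccc(Cl)c3)nc3ccsc23)cn1`) gives > 50000 nM, which is a limit of the assay and not a number. Within the data shown here, compound 2 (`O=S(=O)(Cc1nc(-c2ccc(Cl)nc2)c2sccc2n1)c1cccc(Cl)c1`) reads 70000 nM, the only full number so far.

Compound 3 (`COc1ccc(-c2nc(CSc3cc(C)cc(C)c3)nc3ccsc23)cn1`) carries (3,5-dimethylphenyl)sulfanyl in place of 3-chlorobenzyl on a saturated chain carbon bound to an aromatic carbon. Among the measured compounds shown here, no measured pair shows what such a change does in this assay. The expectation therefore rests on compound 2 at 70000 nM, which keeps the series toward the high end of the read-out.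

The estimated step of an at least 1.1-fold lower number from compound 1 to compound 3 (0.04 log units; that floor lies within the scatter) is small, toward lower numbers if it moves at all, and may stay within the scatter. A reading reported only as a limit is about as likely as a number. For compound 3 the expected value is 45000 nM, with an estimated range of 15000 nM to 100000 nM.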

Compound 3, half-maximal cytotoxic concentration: > 50000 nM
Compound 3: no number, only a limit; the forecaster's own chance of this, stated with the estimate: 50%; middle value at least 1.1-fold (0.04 log units) away from the limit.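

No step can be read from compound 1 to compound 3, because both readings are limits of this assay and not numbers: the limit of > 50000 nM in this assay, at which 2 of the 3 values shown sit.

The compounds shown leave open what (3,5-dimethylphenyl)sulfanyl in place of 3-chlorobenzyl does to this read-out, in either direction.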